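Chain length at the ring amide nitrogen: compound 3 to compound 4

A few compounds are considered here, and "the series" means these few. Any claim that something is new, unique, unknown or untested is made for them only; others in the source may bear on it.

Measured so far in a functional assay on a cell-free system (Platelet, plasma, Homo sapiens) for inhibition; a lower number here means a stronger inhibitor, a higher number a weaker inhibitor:
compound 1 `CC(CC(=O)O)N1Cc2ccc(NC(=O)CC3CCNCC3)cc2C1=O` gives 2700 nM;
compound 2 `O=C(O)CCCN1Cc2ccc(NC(=O)CC3CCNCC3)cc2C1=O` gives 1800 nM;
compound 3 `O=C(O)CN1Cc2ccc(NC(=O)CC3CCNCC3)cc2C1=O` gives 51000 nM.

Compound 3 has the highest number of the three. Its steps are a 19-fold higher number from compound 1 to compound 3 (1.28 log units; beyond the scatter) and a 28-fold higher number from compound 2 to compound 3 (1.45 log units; beyond the scatter), both large; the step of a 1.5-fold lower number from compound 1 to compound 2 (0.18 log units; within the scatter) is within the scatter.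

Compound 4 `O=C(O)CCN1Cc2ccc(NC(=O)CC3CCNCC3)cc2C1=O` differs from compound 3 by carboxymethyl in place of carboxy on a saturated chain carbon bound to an amide-type nitrogen in a ring. Both steps that shorten the chain toward carboxy raise the number by a large amount, so lengthening it again by one carbon is expected to move this assay back toward the numbers of compound 1 and compound 2. For compound 4 a step of a 15-fold lower number from compound 3 to compound 4 (1.16 log units; beyond the scatter) is expected. Compound 4 is therefore estimated at 3500 nM, with a range from 1000 nM to 15000 nM.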

Compound 4, half-maximal inhibitory concentration: 7400 nM
Compound 4: the middle estimate sits 2.1-fold (0.33 log units) below what was measured; the range from low to high includes it.
By their numbers in this assay, from the lowest: compounds 2 and 1 (each within the scatter of the next); then compound 4; then compound 3.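

In this assay, the 2-carboxyethyl chain recovers only part of the loss seen with carboxymethyl: a 6.9-fold lower number from compound 3 to compound 4 (0.84 log units; beyond the scatter), while a 4.1-fold higher number from compound 2 to compound 4 (0.61 log units; beyond the scatter) shows that the 3-carboxypropyl chain gives a lower number still, so across these three compounds the response to chain length is graded. Hydrogen in place of methyl also registers: a 2.7-fold higher number from compound 1 to compound 4 (0.44 log units; beyond the scatter). No measurement here bears on the origin of these steps. From the compounds shown here alone, whether a chain longer than 3-carboxypropyl lowers the number further remains open. So does whether an ester can replace the carboxylic acid.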